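Swapping an Ether Oxygen for an Amine Link

This account rests on a few compounds, and the source may have more. Where it says the series, first, only, none or still open, it means among the compounds named here.

For the measured compounds named here, in a functional assay on MCF7 cells (Homo sapiens) for antiproliferative activity (on this read-out lower numbers stand for stronger inhibition and higher numbers for weaker inhibition), compound 1 `COc1cccc(Oc2ccc3cc(NC(=O)c4ccc(O)c(CC=C(C)C)c4)c(=O)oc3c2C)c1` gives 62800 nM, and compound 2 `CC(C)=CCc1cc(C(=O)Nc2cc3ccc(Oc4ccc(C(C)(C)C)cc4)c(C)c3oc2=O)ccc1O` gives 20600 nM; the step of a 3.0-fold lower number from compound 1 to compound 2 (0.48 log units; beyond the scatter) is the only measured change so far. Compound 3 `COc1ccc(Oc2ccc3cc(NC(=O)c4ccc(OC)c(-c5cccc(OC)c5)c4)c(=O)oc3c2C)cc1` reaches only a limit of the assay, > 100000 nM, and the limit of > 100000 nM in this assay, at which 1 of the 3 values shown sits, marks where it stands. Compound 4 `COc1ccc(Nc2ccc3cc(NC(=O)c4ccc(OC)c(-c5cccc(OC)c5)c4)c(=O)oc3c2C)cc1` differs from compound 3 by (4-methoxyphenyl)amino in place of 4-methoxyphenoxy on an aromatic carbon. The measured step from compound 1 to compound 2 concerns the aryl group on the oxygen, not the linking atom, so it does not bear on this change. With compound 3 already at a limit, compound 4 is expected to stay weak, an estimated 100000 nM (range 30000 nM to 300000 nM), meaning an expected step of a number no higher from compound 3 to compound 4 (the limit leaves the size open).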

Compound 4, half-maximal inhibitory concentration: > 100000 nM
Compound 4: a limit, no number (the forecaster's own chance of this, stated with the estimate: 60%); the middle value sits exactly at the limit.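

Compound 3 and compound 4 both reach only a limit in this assay, and the step between them cannot be read. The compounds shown leave open whether (4-methoxyphenyl)amino or 4-methoxyphenoxy gives stronger inhibition on this shared core.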